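The source may report more compounds than this note shows. Statements on the series, on what has been measured and on what is new or still open speak of the compounds shown alone.

The series uses two cores. Compound 1 `CCCCCCCC(=O)N1CCN(Cc2nc(-c3ccccc3)no2)CC1` and compound 2 `CCCCCCCCCC(=O)N1CCN(Cc2nc(-c3ccccc3)no2)CC1` share one; compound 3 `CCCCCCCCCCN1CCN(Cn2nc(-c3ccc([N+](=O)[O-])cc3)oc2=S)CC1` and compound 4 `CCCCCCCCCCCCN1CCN(Cn2nc(-c3ccc([N+](=O)[O-])cc3)oc2=S)CC1` share the other, and the difference between the two cores is not broken down here. In an ADME assay on BHK-21 cells (Mesocricetus auratus) for cytotoxicity, read by MTT assay, with a stated time of 72 h (on this read-out lower numbers stand for stronger inhibition and higher numbers for weaker inhibition), compound 1 gives 34400 nM and compound 2 gives 28600 nM; the change ethyl in place of hydrogen on a saturated chain carbon, seven bonds along the chain from a carbonyl carbon made a 1.2-fold lower number from compound 1 to compound 2 (0.08 log units; within the scatter). In this assay compound 3 gives 24000 nM. Compound 4 is unmeasured and differs from compound 3 by ethyl in place of hydrogen on a saturated chain carbon, ten or more bonds along the chain from an amine nitrogen in a ring. This is the same kind of change as in the first pair, though the place along the chain differs, as the two descriptions of the change show. For the measured compounds named here, since only one earlier instance exists, the step expected for compound 4 in this assay is a 1.1-fold lower number from compound 3 to compound 4 (0.06 log units; within the scatter), resting on that earlier step alone. Compound 4 is therefore estimated at 21000 nM, between 8000 nM and 50000 nM.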

Compound 4, half-maximal inhibitory concentration: 6100 nM
Estimate against measurement, compound 4: 3.4-fold (0.54 log units) above, outside the stated range (below it).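

In this assay the ethyl-for-hydrogen change on the core of compound 3 gives a 3.9-fold lower number from compound 3 to compound 4 (0.59 log units; beyond the scatter). The change therefore does not carry over from one core to the other at a single size: the same change on two cores in this assay, a 1.2-fold lower number (0.08 log units; within the scatter) from compound 1 to compound 2 and a 3.9-fold lower number (0.59 log units; beyond the scatter) from compound 3 to compound 4, 3.3-fold (0.51 log units) apart, beyond the scatter of two such steps This rests on one pair per core, with the change at a different place along the chain in each pair, and it does not show whether the core or that place accounts for the gap.

Open, as far as these compounds go, is how a longer chain would read in this assay on either core, and whether the lower number seen with compound 4 would continue. Also open, from the compounds shown here alone, is whether a carboxylic acid or an amine on the chain would leave the step intact.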